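Small ester swap on a short-lived compound

A few compounds are considered here, and "the series" means these few. Any claim that something is new, unique, unknown or untested is made for them only; others in the source may bear on it.

Compound 1 `NCc1ccc(C(=O)Nc2ccncc2F)cc1-c1cccc(C(=O)Oc2ccccc2)c1`: 0.117 h
Compound 2 `NCc1ccc(C(=O)Nc2ccncc2F)cc1-c1cccc(C(=O)OCC2CCCCO2)c1`: 0.117 h
Compound 3 `CCCCCOC(=O)c1cccc(-c2cc(C(=O)Nc3ccncc3)ccc2CN)c1`: 0.967 h

In an ADME assay on a cell-free system (plasma, Homo sapiens) for metabolic stability, read by LC-MS (a higher number here means that the compound lasts longer, a lower number that the compound disappears faster), compound 2 stands level with compound 1, the two sharing the lowest of the three numbers, while compound 3 stands well clear of them. Compound 4 `NCc1ccc(C(=O)Nc2ccncc2F)cc1-c1cccc(C(=O)OCC2CCCC2)c1` departs from compound 2 by one change: cyclopentyl in place of oxan-2-yl on a saturated chain carbon bound to an oxygen next to a carbonyl group. Within the data shown here, only one measured step replaces a group on this same oxygen, and no change at the digits printed from compound 1 to compound 2 (within the scatter) lay within the scatter. Among the measured compounds shown here, no measured step connects compound 3 to the others, so its higher number only widens the upper end of the range. On that evidence, the expected result is a small step, a 1.3-fold higher number from compound 2 to compound 4 (0.11 log units; within the scatter), not beyond the scatter. Compound 4 is estimated at 0.15 h, with an expected range of 0.07 h to 0.5 h.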

Compound 4, half-life: 0.283 h
Compound 4: middle estimate off by 1.9-fold (0.28 log units), on the low side, and the stated range covers the measured number.
By their numbers in this assay, from the lowest: compounds 1 and 2 (each within the scatter of the next); then compound 4; then compound 3.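

In this assay, the group on the oxygen next to a carbonyl group now proves able to shift the number: the earlier step gave no change at the digits printed from compound 1 to compound 2 (within the scatter) and so showed no such shift. Cyclopentyl in place of oxan-2-yl gives a 2.4-fold higher number from compound 2 to compound 4 (0.38 log units; beyond the scatter) and cyclopentylmethyl in place of phenyl gives a 2.4-fold higher number from compound 1 to compound 4 (0.38 log units; beyond the scatter) in modest steps. Nothing measured here explains why these groups differ.

On these data alone, whether a longer chain or a tertiary amine on that oxygen would carry the number further remains open.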